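A few compounds are considered here, and "the series" means these few. Any claim that something is new, unique, unknown or untested is made for them only; others in the source may bear on it.

Among the measured compounds shown here, compound 1 `CC1(C)[C@@H]2CC[C@@]1(CS(=O)(=O)N1CCN(c3ccc(Br)cn3)CC1)C(=O)C2` is the only compound here with a measured number: in a functional assay on CHO-K1 cells for antagonist activity at C-X-C chemokine receptor type 3 (Homo sapiens), read by FLIPR and calcium flux (a higher number here means a weaker inhibitor, a lower number a stronger inhibitor), compound 1 gives 1580 nM. Compound 2 `CC1(C)[C@@H]2CC[C@@]1(CS(=O)(=O)N1C[C@@H]3C[C@H]1CN3c1ccc(C(F)(F)F)cn1)C(=O)C2` reaches only a limit in this assay, > 31600 nM, and the limit of > 31600 nM in this assay, at which 1 of the 2 values shown sits, sums up what is known of compound 2. Compound 3 `CC1(C)[C@@H]2CC[C@@]1(CS(=O)(=O)N1CCN(c3ccc([N+](=O)[O-])cn3)CC1)C(=O)C2` differs from compound 1 by nitro in place of bromo on an aromatic carbon, two atoms from the ring nitrogen, para to a large group. For the measured compounds named here, no measured pair in this set makes that change, so the data give no direction for it. The step of a 1.0-fold higher number from compound 1 to compound 3 (0.01 log units; within the scatter) is expected to stay within the usual scatter. Compound 3 is therefore estimated at 1600 nM, between 500 nM and 6000 nM.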

Compound 3, half-maximal inhibitory concentration: > 31600 nM
Compound 3 was reported as a limit; the forecaster's own chance of this, stated with the estimate: 10%; middle value at least 19-fold (1.29 log units) from the limit.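

In this assay, replacing 5-bromopyridin-2-yl with 5-nitropyridin-2-yl gives an at least 20-fold higher number from compound 1 to compound 3 (1.30 log units; beyond the scatter). Among the compounds shown here, this is the first direct reading at this position, para to a large group, and it shows that the activity of compound 1 does not survive every replacement of bromo there. The value of compound 3 is a limit, not a number: the limit of > 31600 nM in this assay, at which 2 of the 3 values shown sit.

Going by these compounds, only bromo and nitro can be compared at this position, so it remains open how a nitrile, a methoxy or an amine would read there. On these data alone, the full size of the step also stays open.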